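Naphthyl for Tolyl on a Sulfonamide-Triazole Core

The compounds below may be only part of what the source reports. "The series", "measured", "known", "first", "only" and "open" are said of these compounds alone.

Compound 1 `Cc1ccc(OCc2cn(-c3ccc(S(=O)(=O)N4CCc5ccccc5C4)cc3)nn2)cc1` in a functional assay on A549 cells (Homo sapiens) for cytotoxicity, read by MTT assay, with a stated time of 48 h; a lower number here means a stronger inhibitor, a higher number a weaker inhibitor: compound 1 gives > 50 ug/mL, a limit of the assay.
Compound 2 `COc1cc2c(cc1OC)CN(S(=O)(=O)c1ccc(-n3cc(COc4ccc5ccccc5c4)nn3)cc1)CC2`: compound 2 gives > 50 ug/mL, likewise a limit.
Compound 3 `COc1cc2c(cc1OC)CN(S(=O)(=O)c1ccc(-n3cc(COc4ccc(C)cc4)nn3)cc1)CC2`: compound 3 gives > 50 ug/mL, again a limit.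

Compound 1 therefore stands only at a limit, as do both of its companions, all three sitting at the limit of > 50 ug/mL in this assay, at which 3 of the 3 values shown sit. Compound 4 `O=S(=O)(c1ccc(-n2cc(COc3ccc4ccccc4c3)nn2)cc1)N1CCc2ccccc2C1` differs from compound 1 by naphthalen-2-yl in place of 4-methylphenyl on an oxygen on a saturated carbon. Going by the values given here, the one comparable measured step, a step that the two limits leave unreadable from compound 2 to compound 3, is the same exchange run backwards on the dimethoxy core, and its limits make its size unreadable. Among the compounds with values here, no step here shows a readable shift in this assay, so no movement beyond the scatter is expected. Compound 4 is expected to give about 70 ug/mL, between 30 ug/mL and 160 ug/mL, a step that the limit leaves unreadable from compound 1 to compound 4 from compound 1.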

Compound 4, half-maximal inhibitory concentration: > 50 ug/mL
Compound 4 gave a limit, no number; the forecaster's own chance of this, stated with the estimate: 80%; the middle value lies beyond the limit too.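

No step can be read from compound 1 to compound 4, as both values are limits rather than numbers: the limit of > 50 ug/mL in this assay, at which 4 of the 4 values shown sit.

The compounds shown leave open whether exchanging 4-methylphenyl for naphthalen-2-yl alters potency in this assay at all.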